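Cyano Substitution on an Inactive Propargylamine Scaffold

The source may report more compounds than this note shows. Statements on the series, on what has been measured and on what is new or still open speak of the compounds shown alone.

Measured compounds:
Compound 1, `C#CCN(CCC1CCN(Cc2ccccc2)CC1)Cc1ccc2cccc(O)c2n1`, in an assay on isolated protein for inhibition of Amine oxidase [flavin-containing] B (Homo sapiens), read by fluorescence and Amplex Red, with stated times of 30 min and 1 h; a higher number here means a weaker inhibitor, a lower number a stronger inhibitor: > 100000 nM.
Compound 2, `C#CCN(CCCC1CCN(Cc2ccccc2)CC1)Cc1ccc2cccc(O)c2n1`, in this assay: > 100000 nM.

Compound 1 stands at a limit in this assay: its result of > 100000 nM is a limit of the assay and not a number. The same holds for compound 2, whose value > 100000 nM is also a limit, so that (the limit of > 100000 nM in this assay, at which 2 of the 2 values shown sit). Within the data shown here, both compounds share the same core and differ only in the length of the saturated chain that joins the core to the ring bearing the benzyl group; no step between them can be computed, and the two values show only that neither reaches a measurable inhibition.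

Compound 3, `C#CCN(Cc1ccc2cccc(O)c2n1)C(C#N)CC1CCN(Cc2ccccc2)CC1`, is not yet measured. It differs from compound 1 by cyano in place of hydrogen on a saturated chain carbon bound to an amine nitrogen and a saturated chain carbon. Among the measured compounds shown here, with both known compounds at the limit, there is no measured step on which to build. The step from compound 1 to compound 3 is therefore expected to be small or absent, as a number no higher from compound 1 to compound 3 (the limit leaves the size open) indicates. Compound 3 is estimated at 100000 nM, within a range from 20000 nM to 300000 nM, with a considerable chance that the assay again reports only a limit.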

Compound 3, half-maximal inhibitory concentration: > 100000 nM
Compound 3 was reported as a limit (the forecaster's own chance of this, stated with the estimate: 70%); the middle value sits exactly at the limit.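

Among these compounds, no step from compound 1 to compound 3 can be read, because both results are limits of the assay and not numbers: the limit of > 100000 nM in this assay, at which 3 of the 3 values shown sit. The compounds shown leave open how strongly, if at all, each one inhibits in this assay, and whether cyano in place of hydrogen changes that result.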